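Removing a Hydroxyethoxy Group from a Dihydroxyethoxy Analogue

This account rests on a few compounds, and the source may have more. Where it says the series, first, only, none or still open, it means among the compounds named here.

Of the compounds shown here, three have been measured in an assay on C6 cells for antagonist activity at prostaglandin E2 receptor EP2 subtype (Homo sapiens), read by TR-FRET, with stated times of 10 min and 40 min, tested at 1 uM; on this read-out lower numbers stand for stronger inhibition and higher numbers for weaker inhibition. Compound 1 `COc1cc(/C=C/C(=O)NCCn2c(C)cc3ccccc32)cc(OC)c1` gives 3.4 nM, compound 2 `COc1cc(/C=C/C(=O)NCCn2c(C)cc3ccccc32)cc(OC)c1OCCO` gives 3.7 nM, and compound 3 `Cc1cc2ccccc2n1CCNC(=O)/C=C/c1ccc(OCCO)c(OCCO)c1` gives 11.4 nM, the highest number of the three and beyond the scatter from both others. Compound 2 and compound 1 differ by hydrogen in place of 2-hydroxyethoxy on an aromatic carbon and the step is a 1.1-fold lower number from compound 2 to compound 1 (0.04 log units; within the scatter). Compound 3 and compound 2 contain the same atoms joined differently; the difference between the two cores is not broken down here.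

Compound 4 `Cc1cc2ccccc2n1CCNC(=O)/C=C/c1ccc(OCCO)cc1` has not yet been measured in this assay. It differs from compound 3 by hydrogen in place of 2-hydroxyethoxy on an aromatic carbon. This is the same kind of change as that from compound 2 to compound 1, but the place differs: here the leaving group sits ortho to a 2-hydroxyethoxy group and meta to a large group, whereas in compound 2 it sat ortho to two methoxy groups and para to a large group. Because a 1.1-fold lower number from compound 2 to compound 1 (0.04 log units; within the scatter) stayed within the scatter, the step from compound 3 to compound 4 is expected to be small, about a 1.3-fold lower number from compound 3 to compound 4 (0.10 log units; within the scatter). Compound 4 is therefore estimated at 9 nM, with a likely range of 3.5 nM to 25 nM.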

Compound 4, antagonist equilibrium constant in the prostaglandin E2 receptor EP2 subtype assay: 13.6 nM
The estimate for compound 4 lay 1.5-fold (0.18 log units) below the measured number; the measured number falls inside the stated range.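

In the prostaglandin E2 receptor EP2 subtype assay, replacing this 2-hydroxyethoxy group by hydrogen gave a 1.2-fold higher number from compound 3 to compound 4 (0.08 log units; within the scatter), a step that stays within the usual scatter. Set beside the earlier case, the same change behaved alike on the two cores, even though it took place at different positions on the aromatic ring: the same change on two cores in the prostaglandin E2 receptor EP2 subtype assay, a 1.1-fold lower number (0.04 log units; within the scatter) from compound 2 to compound 1 and a 1.2-fold higher number (0.08 log units; within the scatter) from compound 3 to compound 4, 1.3-fold (0.11 log units) apart, within the scatter of two such steps. For the compounds shown here, these two pairs show only that the change was tolerated on these two cores, not that it would be tolerated on any other core or at any other position, and the one step beyond the scatter comes from a single core, in a physicochemical assay for solubility, read by nephelometry, in phosphate buffer, at pH 7.4; a lower number here means a less soluble compound, a higher number a more soluble compound: the measured solubility of compound 3, 153000 nM, and of compound 4, 68000 nM, a 2.3-fold lower number (0.35 log units; beyond the scatter). In the physicochemical assay compound 3 gives 153000 nM and compound 4 gives 68000 nM.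

The compounds shown leave open whether the number in the prostaglandin E2 receptor EP2 subtype assay would hold if the 2-hydroxyethoxy group gave way to something other than hydrogen, such as an amine, a carboxylic acid or a longer chain. As far as these compounds go, whether the step seen in the physicochemical assay recurs on the core of compound 1 also remains open.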